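Anilino variation in a triazole-linked nitrile series

The compounds below may be only part of what the source reports. "The series", "measured", "known", "first", "only" and "open" are said of these compounds alone.

Measured so far:
compound 1 `CC(C)c1ccc(-c2nc(SCc3cn(CC(=O)NC(=O)Nc4ccccn4)nn3)nc(Nc3ccccc3Cl)c2C#N)cc1`, 19700 nM
compound 2 `CC(C)c1ccc(-c2nc(SCc3cn(CC(=O)NC(=O)Nc4ccccn4)nn3)nc(Nc3ccccc3O)c2C#N)cc1`, 16400 nM

In a functional assay on MGC-803 cells (Homo sapiens) for inhibition, read by MTT assay, with a stated time of 72 h (on this read-out lower numbers stand for stronger inhibition and higher numbers for weaker inhibition), compound 2 gives 16400 nM, the lowest of the two numbers; compound 1 gives 19700 nM, a gap that is within the scatter, so no order between them is claimed. Going by the values given here, the one measured step, a 1.2-fold lower number from compound 1 to compound 2 (0.08 log units; within the scatter), concerns the substituent on the anilino ring only. Compound 3 `CC(C)c1ccc(Nc2nc(SCc3cn(CC(=O)NC(=O)Nc4ccccn4)nn3)nc(-c3ccc(C(C)C)cc3)c2C#N)cc1` differs from compound 2 by 4-isopropylphenyl in place of 2-hydroxyphenyl on a nitrogen on an aromatic ring. Among the compounds with values here, no measured step covers this exchange, so no direction is expected beyond the scatter, and the range must stay wide. Compound 3 is estimated at 20000 nM in this assay, between 8000 nM and 50000 nM, an expected step of a 1.2-fold higher number from compound 2 to compound 3 (0.09 log units; within the scatter).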

Compound 3, half-maximal inhibitory concentration: 15800 nM
Compound 3: the middle estimate sits 1.3-fold (0.10 log units) above what was measured; low and high end bracket the measured number.
By their numbers in this assay, from the lowest: compounds 3, 2 and 1 (each within the scatter of the next).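

In this assay, 4-isopropylphenyl in place of 2-hydroxyphenyl on a nitrogen on an aromatic ring gives a 1.0-fold lower number from compound 2 to compound 3 (0.02 log units; within the scatter) and in place of 2-chlorophenyl gives a 1.2-fold lower number from compound 1 to compound 3 (0.10 log units; within the scatter) as the result. A group with no hydrogen-bond donors or acceptors therefore leaves all three compounds within the scatter of one another. No supporting evidence bears on this flat reading. As far as these compounds go, whether an amine or a carboxylic acid on this ring, or a plain alkyl chain in its place, would move the number beyond the scatter stays open. Also open, from the compounds shown here alone, is how unsubstituted phenyl reads here.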